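Cyclopent-1-en-1-yl in place of furan-2-yl on compound 2

The source may hold more compounds than are shown below. What is called first, only, known or untested is meant among the compounds shown, and "the series" means these compounds.

Two values are in hand. In a functional assay on MT2 cells (Homo sapiens) for cytotoxicity, read by MTT assay (on this read-out higher numbers stand for lower toxicity in this test and lower numbers for higher toxicity in this test), compound 1 (`CC(C)=CCOc1cc(Nc2nccs2)ccc1C`) gives 17000 nM and compound 2 (`N#Cc1ccc(Nc2nccs2)cc1OCc1ccco1`) gives 18000 nM as its reading. Compound 2 therefore stands level with compound 1, the two numbers lying within the scatter of each other, and neither can be ranked. Among the measured compounds shown here, no measured pair differs in only one place, so no single change can be sized directly.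

Compound 3 (`N#Cc1ccc(Nc2nccs2)cc1OCC1=CCCC1`) comes from compound 2 by one change (cyclopent-1-en-1-yl in place of furan-2-yl on a saturated chain carbon bound to an oxygen on an aromatic ring) with cyclopent-1-en-1-yl in place of furan-2-yl on a saturated chain carbon bound to an oxygen on an aromatic ring. The (furan-2-yl)methoxy thus becomes (cyclopent-1-en-1-yl)methoxy.

No step beyond the scatter is expected in this assay for this change. Compound 1 carries no furan-2-yl and still reads 17000 nM in this test, though two values make only thin support. The expected change is a 1.1-fold lower number from compound 2 to compound 3 (0.02 log units; within the scatter) and it is estimated to stay within the scatter. For compound 3 the estimated value is 17000 nM with an expected range from 8000 nM to 38000 nM in this test.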

Compound 3, half-maximal cytotoxic concentration: 1700 nM
Estimate against measurement, compound 3: 10-fold (1.00 log units) above, outside the stated range (below it).
By their numbers in this assay, from the lowest: compound 3; then compounds 1 and 2 (each within the scatter of the next).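

In this assay, among the compounds shown here, the group on a saturated chain carbon bound to an oxygen on an aromatic ring proves able to move the read-out: cyclopent-1-en-1-yl in place of furan-2-yl gives an 11-fold lower number from compound 2 to compound 3 (1.02 log units; beyond the scatter) and, with it, the first single change that can be sized directly, a large one toward higher toxicity in this test. The heavy-atom count and the five-membered ring size stay the same, so this step comes with a change of ring type and the loss of the ring oxygen and its hydrogen-bond acceptor, not with a change in either of those two counts. Nothing available gives a cause for the step.

For the compounds shown here, the single pair cannot separate the loss of the ring oxygen from the loss of the aromatic ring, since both changes arrive together. Thiophen-2-yl, phenyl or saturated cyclopentyl on the same saturated chain carbon would be needed to tell these apart, and whether the step holds with a group other than the nitrile on the core remains open.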